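This account rests on a few compounds, and the source may have more. Where it says the series, first, only, none or still open, it means among the compounds named here.

Compound 1 `CCCCCCOc1ccc(-n2cnnc2CC)cc1` is the starting point: in a functional assay on the whole organism (strain C57B/6) with Mus musculus as the target, in the maximal electroshock model (on this read-out lower numbers stand for an effect already at smaller amounts and higher numbers for an effect only at larger amounts of compound), compound 1 gives 13.2 mg/kg. Compound 2 `CCCCCCOc1ccc(-n2cnnc2CCCCCC)cc1` carries a longer chain on the core, and that lengthening brought an at least 3.0-fold higher number from compound 1 to compound 2 (0.48 log units; beyond the scatter). In this assay compound 2 reaches only a limit of the assay, > 40 mg/kg. Compound 3 `CCCCCCCCCc1nncn1-c1ccc(OCCCCCC)cc1` carries a still longer chain, giving an at least 3.0-fold higher number from compound 1 to compound 3 (0.48 log units; beyond the scatter). In this assay compound 3 likewise stops at a limit, > 40 mg/kg. Because both sit at the limit of > 40 mg/kg in this assay, at which 2 of the 3 values shown sit, the step that the two limits leave unreadable from compound 2 to compound 3 cannot be read. Compound 4 `CCCCCCOc1ccc(-n2cnnc2Cc2ccccc2)cc1` is compound 2 with phenyl in place of pentyl on a saturated chain carbon bound to an aromatic carbon. Going by the values given here, no measured step swaps a chain for a ring; the two readable steps show only that extra chain length raised the dose needed, and this swap shortens the chain. The expected dose for compound 4 in this assay is therefore 20 mg/kg, between 8 mg/kg and 40 mg/kg, an estimated at least 2.0-fold lower number from compound 2 to compound 4 (0.30 log units; that floor lies within the scatter).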

Compound 4, dose for half-maximal effect: 19 mg/kg
For compound 4 the middle estimate is 1.1-fold (0.02 log units) above the measured one; measured number inside the range.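

In this assay, a phenyl ring at this saturated chain carbon bound to an aromatic carbon does not carry the cost seen with the long chains: there is an at least 2.1-fold lower number from compound 2 to compound 4 (0.32 log units; beyond the scatter), and an at least 2.1-fold lower number from compound 3 to compound 4 (0.32 log units; beyond the scatter). Both steps are only floors, as compound 2 and compound 3 each stop at a limit of the assay: the limit of > 40 mg/kg in this assay, at which 2 of the 4 values shown sit. Against the short chain there is a 1.4-fold higher number from compound 1 to compound 4 (0.16 log units; within the scatter), so the ring keeps the level of compound 1.

On these data alone, it remains open whether a propyl chain would hold this level. The effect of a chlorine atom or a methoxy group on the new phenyl ring is also unknown.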